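The source may hold more compounds than are shown below. What is called first, only, known or untested is meant among the compounds shown, and "the series" means these compounds.

Three compounds share one core and differ only in the side chain on the saturated chain carbon bound to an amide-type nitrogen and a carbonyl carbon. In a functional assay on the whole organism (Tail, strain ICR) with Mus musculus as the target, in the tail flick test, with a stated time of 30 min, at a dose of 25 umol/kg by the oral route (on this read-out higher numbers stand for a stronger effect at the one dose given and lower numbers for a weaker effect), compound 1 `NC(=O)C[C@H](NC(=O)CN(c1nc(Cl)nc2[nH]cnc12)C1CC1)C(=O)O` gives 29.7%, and compound 2 `O=C(O)CC[C@H](NC(=O)CN(c1nc(Cl)nc2[nH]cnc12)C1CC1)C(=O)O` gives 26.8%, with a number 2.9 percentage points lower from compound 1 to compound 2 (within the scatter). Compound 3 `C[C@@H](O)[C@H](NC(=O)CN(c1nc(Cl)nc2[nH]cnc12)C1CC1)C(=O)O` gives 18.6% in this assay, the smallest of the three numbers. Compound 4 `NCCCC[C@H](NC(=O)CN(c1nc(Cl)nc2[nH]cnc12)C1CC1)C(=O)O` has not yet been measured, and its change from compound 3 is 4-aminobutyl in place of 1-hydroxyethyl on a saturated chain carbon bound to an amide-type nitrogen and a carbonyl carbon. The steps at this same position, a number 11.1 percentage points lower from compound 1 to compound 3 (beyond the scatter) and a number 8.2 percentage points lower from compound 2 to compound 3 (within the scatter), were small, so only a small rise is expected for compound 4 in this assay, a number 6.4 percentage points higher from compound 3 to compound 4 (within the scatter). Compound 4 is therefore estimated to give 25%, within a range from 10% to 40%.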

Compound 4, a percentage reported as activity, at one dose (the size of the read-out at that dose, not a potency): 31.2%
Compound 4: middle estimate off by 6.2 percentage points, on the low side; the range from low to high includes it.
By their numbers in this assay, from the lowest: compounds 3, 2, 1 and 4 (each within the scatter of the next, the first and the last beyond it).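

In this assay the change to 4-aminobutyl gives a number 12.6 percentage points higher from compound 3 to compound 4 (beyond the scatter) and so shows that this position can carry a long side chain ending in an amine without losing the effect. The steps of a number 4.4 percentage points higher from compound 2 to compound 4 (within the scatter) and a number 1.5 percentage points higher from compound 1 to compound 4 (within the scatter) show that side chains ending in an amine, a carboxylic acid or an amide cannot be told apart here, while 1-hydroxyethyl separates only from the amine and the amide. On these data alone, whether the amine itself or the chain length matters stays open, and a plain butyl chain or a guanidine at the chain end would help separate the two. Nothing measured here explains these steps.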